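A few compounds are considered here, and "the series" means these few. Any claim that something is new, unique, unknown or untested is made for them only; others in the source may bear on it.

Working notes on the series.

Two compounds of the shared core have numbers in an assay on isolated protein for antagonist activity at Voltage-dependent L-type calcium channel subunit alpha-1C (Cavia porcellus), with a stated time of 15 min; on this read-out higher numbers stand for weaker inhibition and lower numbers for stronger inhibition. Compound 1 `CCOC(=O)C1=C(C)NC(C)=C(C(=O)OCC)C1c1csc(-c2ccc(Cl)cc2)n1` carries two ethyl esters and in this assay gives 3650 nM. Compound 2 `COC(=O)C1=C(C)NC(C)=C(C(=O)OC(C)(C)C)C1c1csc(-c2ccc(Cl)cc2)n1` carries a methyl ester and a tert-butyl ester and in this assay gives 46000 nM. Compound 1 stands at the lower of the two numbers, and the gap to compound 2 lies beyond the scatter; the two compounds differ in two places, so nothing is computed as a single step between them.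

Compound 3 `CCOC(=O)C1=C(C)NC(C)=C(C(=O)OC2CCCC2)C1c1csc(-c2ccc(Cl)cc2)n1` is the next compound, not yet measured in this assay. It differs from compound 1 in one place: cyclopentyl in place of ethyl on an oxygen next to a carbonyl group. Among the measured compounds shown here, the only comparison available, compound 1 against compound 2, points toward larger ester groups going with higher numbers, but it rests on one pair and two changes at once. For compound 3 a modest step toward a higher number is expected, a 1.9-fold higher number from compound 1 to compound 3 (0.28 log units; within the scatter), smaller than the gap between compound 1 and compound 2. The estimate for compound 3 in this assay is 7000 nM, with a range from 1800 nM to 28000 nM.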

Compound 3, half-maximal inhibitory concentration: 8380 nM
Compound 3: middle estimate off by 1.2-fold (0.08 log units), on the low side; low and high end bracket the measured number.
By their numbers in this assay, from the lowest: compound 1; then compound 3; then compound 2.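

In this assay, a change at one ester alone can now be read, with the other ester left as ethyl: cyclopentyl in place of ethyl on an oxygen next to a carbonyl group gives a 2.3-fold higher number from compound 1 to compound 3 (0.36 log units; beyond the scatter). The earlier gap came with two changes at once and could not be assigned to either ester, whereas this step ties a modest rise in the number to the group on this oxygen alone. No measurement on hand bears on why the number moves with this change.

With one step at this position, the compounds shown do not separate the ring from the larger carbon count, and an open-chain pentyl, a cyclopropyl or a cyclohexyl group on the same oxygen would bear on that question. Also open, as far as these compounds go, are how the number responds when this group carries atoms other than carbon, as in a methoxyethyl or aminoethyl chain or in the free carboxylic acid, and whether the same change at the other ester gives a similar step.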